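Turning One Stereocentre in a Weak Diacid Amide

A few compounds are considered here, and "the series" means these few. Any claim that something is new, unique, unknown or untested is made for them only; others in the source may bear on it.

- Compound 1 `CCn1c(C(=O)NCCO)ccc1C(CC)(CC)c1ccc(OCS(=O)(=O)c2ccccc2)c(C)c1`: 19900 nM
- Compound 2 `CCn1c(C(=O)N[C@H](CC(=O)O)C(=O)O)ccc1C(CC)(CC)c1ccc(OCS(=O)(=O)c2ccccc2)c(C)c1`: > 50000 nM (a limit)
- Compound 3 `CCn1c(C(=O)N[C@@H](CCC(=O)O)C(=O)O)ccc1C(CC)(CC)c1ccc(OCS(=O)(=O)c2ccccc2)c(C)c1`: > 50000 nM (a limit)

All three compounds were tested in a functional assay on BXPC-3 cells (Homo sapiens) for antiproliferative activity, read by MTT assay, with a stated time of 24 h; a lower number here means a stronger inhibitor, a higher number a weaker inhibitor. Compound 3 has no exact number, only a limit of the assay: > 50000 nM. Compound 3 thus sits at the limit of > 50000 nM in this assay, at which 2 of the 3 values shown sit.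

Compound 4 `CCn1c(C(=O)N[C@H](CCC(=O)O)C(=O)O)ccc1C(CC)(CC)c1ccc(OCS(=O)(=O)c2ccccc2)c(C)c1` has the same atoms and bonds as compound 3, and only its configuration differs: the two compounds have the same atoms and bonds and differ only in configuration as drawn: 1 of 1 stereo elements differ; a stereocentre at a saturated chain carbon is drawn S in compound 3 and R in compound 4. Within the data shown here, no measured step changes configuration alone, so the evidence is indirect. The closest guide is the step that put 1,3-dicarboxypropyl in place of 2-hydroxyethyl on an amide-type nitrogen, which is an at least 2.5-fold higher number from compound 1 to compound 3 (0.40 log units; beyond the scatter). The change to 1,2-dicarboxyethyl was similar, an at least 2.5-fold higher number from compound 1 to compound 2 (0.40 log units; beyond the scatter). The remaining comparison, a step that the two limits leave unreadable from compound 2 to compound 3, joins two limits and gives no size.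

Compound 4 keeps the 1,3-dicarboxypropyl group, which was present in compound 3 at > 50000 nM, so it is expected to remain weak in this assay. No step beyond the scatter is expected in either direction, and the assay will probably report a limit again. The expected step is a step that the limit leaves unreadable from compound 3 to compound 4. For compound 4 the estimated value is 55000 nM, within an expected range of 25000 nM to 120000 nM.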

Compound 4, half-maximal inhibitory concentration: > 50000 nM
Compound 4: a limit, no number; the forecaster's own chance of this, stated with the estimate: 80%; the middle value is on the limit's open side.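

Compound 4 stays out of reach of a readable number in this assay, so inverting this one stereocentre of the 1,3-dicarboxypropyl group, from S as drawn to R, does not bring the compound into the measurable range: the limit of > 50000 nM in this assay, at which 3 of the 4 values shown sit. Measured against the 2-hydroxyethyl group on the amide-type nitrogen, the R form shows an at least 2.5-fold higher number from compound 1 to compound 4 (0.40 log units; beyond the scatter), and the S form gave a step of the same printed size. The steps that link compound 4 to compound 3 and to compound 2 join two limits and cannot be read, so any effect of configuration stays hidden even in the cleanest comparison available: the fact that compounds 3 and 4 differ only in the configuration as drawn.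

Among the compounds shown, only compound 1 has an exact value, 19900 nM, so the series gives no measured size for any change among the diacids. From the compounds shown here alone, it remains open whether a single carboxylic acid, as in a carboxymethyl group on the amide-type nitrogen, would give a readable number, and the same goes for an amine such as 2-aminoethyl or a longer chain such as 3-hydroxypropyl.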